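Formyl on a Ring Nitrogen and Paw Edema Inhibition

The source may report more compounds than this note shows. Statements on the series, on what has been measured and on what is new or still open speak of the compounds shown alone.

Three compounds have been measured in a functional assay on the whole organism (strain Wistar) for inhibition, with Rattus norvegicus as the target, read by paw edema, with stated times of 30 min and 60 min, at a dose of 50 mg/kg by the oral route; a higher number here means more inhibition at the dose given (going by the name of the read-out), a lower number less inhibition:
compound 1, `O=CN1N=C(c2ccc(F)cc2)CC1c1cn(-c2ccccc2)nc1-c1ccc(Cl)c(Cl)c1`, 56.5%
compound 2, `Cc1ccc(C2=NNC(c3cn(-c4ccccc4)nc3-c3ccc(Cl)c(Cl)c3)C2)cc1`, 56.5%
compound 3, `Fc1ccc(C2=NNC(c3cn(-c4ccccc4)nc3-c3ccc(Cl)c(Cl)c3)C2)cc1`, 40.5%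

Compound 1 and compound 3 differ in one place: formyl in place of hydrogen on an amine nitrogen in a ring. That change gave a number 16 percentage points higher from compound 3 to compound 1 (beyond the scatter). Compound 2 and compound 3 differ in another single place: methyl in place of fluoro on an aromatic carbon. That change gave a number 16 percentage points lower from compound 2 to compound 3 (beyond the scatter). Compound 1 and compound 2 stand level with each other within the scatter.

Compound 4, `Cc1ccc(C2=NN(C=O)C(c3cn(-c4ccccc4)nc3-c3ccc(Cl)c(Cl)c3)C2)cc1`, has not been measured. It differs from compound 2 in formyl in place of hydrogen on an amine nitrogen in a ring. Going by the values given here, this is the same kind of change as the one from compound 3 to compound 1; the two places differ only in that the ring atom two ring bonds away bears a 4-methylphenyl group in compound 2 and a 4-fluorophenyl group in compound 3. Among the compounds with values here, the only guide is that single step, seen once. Compound 2 already stands at 56.5%. In this assay the expected step is a number 11.5 percentage points higher from compound 2 to compound 4 (beyond the scatter), because the same kind of change gave a number 16 percentage points higher from compound 3 to compound 1 (beyond the scatter). Compound 4 is estimated at 68%, between 55% and 80%.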

Compound 4, a percentage reported as inhibition, in the whole organism at one dose (the size of the read-out at that dose, not a potency): 53.4%
Estimate against measurement, compound 4: 14.6 percentage points above; measured number below the stated range.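

In this assay, formyl in place of hydrogen on the amine nitrogen in the ring gave a number 3.1 percentage points lower from compound 2 to compound 4 (within the scatter), so the gain seen with the 4-fluorophenyl group did not carry over to the core bearing the 4-methylphenyl group: the same change on two cores in this assay, a number 16 percentage points higher (beyond the scatter) from compound 3 to compound 1 and a number 3.1 percentage points lower (within the scatter) from compound 2 to compound 4, 19.1 percentage points apart, beyond the scatter of two such steps. The exchange on the aromatic carbon likewise depended on its setting, for with formyl present, methyl in place of fluoro gave a number 3.1 percentage points lower from compound 1 to compound 4 (within the scatter), unlike the step seen without formyl: the same change on two cores in this assay, a number 16 percentage points lower (beyond the scatter) from compound 2 to compound 3 and a number 3.1 percentage points higher (within the scatter) from compound 4 to compound 1, 19.1 percentage points apart, beyond the scatter of two such steps. These four compounds show that the two changes do not simply add up here, but they do not show why, nor how either change would behave on any other core, since the comparison rests on a single pair of steps at one dose.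

The compounds shown leave open whether an acetyl group on that ring nitrogen would behave as formyl does on these two cores. They also leave open how a chloro or methoxy group in place of methyl on the aromatic carbon would fit this picture.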